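The source may report more compounds than this note shows. Statements on the series, on what has been measured and on what is new or still open speak of the compounds shown alone.

Measured in a functional assay on KB cells (Homo sapiens) for cytotoxicity, read by MTT assay, with a stated time of 72 h; a lower number here means a stronger inhibitor, a higher number a weaker inhibitor:
compound 1 (`COc1ccc(S(=O)(=O)c2nc3ccccc3nc2Nc2ccccc2)cc1`): 9890 nM
compound 2 (`COc1ccc(Nc2nc3ccccc3nc2S(=O)(=O)c2ccc(OC)cc2)cc1`): "not determined" (no result reported)
compound 3 (`COc1ccc(S(=O)(=O)c2nc3ccccc3nc2Nc2cc(OC)cc(OC)c2)cc1`): "not determined" (no result reported)

Compound 3 has no single number in this assay ("not determined" (no result reported)) and so offers no baseline of its own. Compound 2 has none either, which leaves compound 1 as the only measured reference for the series.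

Compound 4 (`COc1ccc(S(=O)(=O)c2nc3ccccc3nc2Nc2cccc(N)c2)cc1`) carries 3-aminophenyl in place of 3,5-dimethoxyphenyl on a nitrogen on an aromatic ring. The size of this step cannot be read from the data, since only one end of it could ever carry a number. For the measured compounds named here, compound 1 shares the core and has an unsubstituted phenyl on that nitrogen, and its value (9890 nM) is the sole guide. Nothing measured points to a direction, so no shift beyond the scatter around that value is expected in this assay, although the uncertainty is wide. For compound 4 the expected value is 8000 nM (estimated range 2000 nM to 30000 nM).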

Compound 4, half-maximal inhibitory concentration: 4960 nM
Beside the measured number, compound 4's estimate is 1.6-fold (0.21 log units) above it; measured number inside the range.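

On a nitrogen on an aromatic ring, the series now has its first readable step in this assay: amino in place of hydrogen on an aromatic carbon gives a 2.0-fold lower number from compound 1 to compound 4 (0.30 log units; within the scatter), so on these data 3-aminophenyl and the unsubstituted phenyl of compound 1 cannot be told apart. Steps to or from compound 2 and compound 3 cannot be read, as neither compound has a number, and the effect of the methoxy-bearing groups at this position remains unknown. No supporting measurement bears on this result.

Open, going by these compounds, is whether a carboxylic acid, a hydroxyl or an acetamide in place of the amino group would give a step from compound 1 beyond the scatter. Also open, on these data alone, is what a chlorine in place of the methoxy group on the shared core would do in this assay.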